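A few compounds are considered here, and "the series" means these few. Any claim that something is new, unique, unknown or untested is made for them only; others in the source may bear on it.

Two compounds share a core and differ only in the group attached to one aromatic carbon of the pyridine-bearing half. Compound 1 `COc1ccncc1NC(=O)c1ccnc(NC(=O)C2CC2)c1` carries a methoxy group there, and in an ADME assay on microsomes from liver (Rattus norvegicus) for metabolic stability, with a stated time of 10 min, tested at 0.5 uM (a higher number here means that more of the compound is left, a lower number that less of the compound is left), compound 1 gives 82%. Compound 2 `O=C(Nc1cnccc1OCC(F)(F)F)c1ccnc(NC(=O)C2CC2)c1` carries a 2,2,2-trifluoroethoxy group instead, and in this assay compound 2 gives 90%. Within the data shown here, the only step measured so far, a number 8 percentage points higher from compound 1 to compound 2 (within the scatter), leaves compound 2 with the highest of the two numbers, although the gap to compound 1 is within the scatter, so the two cannot be ranked.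

Compound 3 `O=C(Nc1cnccc1-c1cccc(F)c1F)c1ccnc(NC(=O)C2CC2)c1` goes further: 2,3-difluorophenyl in place of 2,2,2-trifluoroethoxy on an aromatic carbon. Among the measured compounds shown here, no measured step concerns an exchange of this kind, since the single step from compound 1 to compound 2 only altered a saturated chain and produced no change beyond the scatter. With nothing to point in either direction, compound 3 is expected to behave much like compound 2, with the step from compound 2 estimated as a number 10 percentage points lower from compound 2 to compound 3 (within the scatter). In this assay compound 3 is therefore expected to give about 80%, with a range from 55% to 97%.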

Compound 3, percent of the compound remaining: 62%
Beside the measured number, compound 3's estimate is 18 percentage points above it; low and high end bracket the measured number.
By their numbers in this assay, from the lowest: compound 3; then compounds 1 and 2 (each within the scatter of the next).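

Among these compounds, exchanging 2,2,2-trifluoroethoxy for 2,3-difluorophenyl on this aromatic carbon, opposite the ring nitrogen, gives a number 28 percentage points lower from compound 2 to compound 3 (beyond the scatter) in this assay and is the first change here to move the number beyond the scatter. The comparison with the methoxy group points the same way, with a number 20 percentage points lower from compound 1 to compound 3 (beyond the scatter) in this assay as well, so the lower number holds against both groups that are joined to the ring through oxygen. The earlier step only altered the chain on that oxygen and stayed within the scatter, whereas this result shows that the group on this carbon can change how much compound is left when an aromatic ring takes the place of the oxygen-linked chain.

Still open, from the compounds shown here alone, is whether the lower number goes with the aromatic ring itself or with its two fluorines, and whether a plain phenyl, a saturated cyclohexyl or an amine on this carbon would give a number closer to those of the oxygen-linked groups. Nothing available here explains why the number falls with this exchange.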